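Aryl exchange on the shared core: compound 1 to compound 4

This account rests on a few compounds, and the source may have more. Where it says the series, first, only, none or still open, it means among the compounds named here.

Among the three numbers measured in a functional assay (muscle tissue) with Cavia porcellus as the target (on this read-out lower numbers stand for an effect already at smaller amounts and higher numbers for an effect only at larger amounts of compound), compound 1 `COC(=O)C1=C(C)N=C(C)/C(=C(\O)OC)C1c1ccccc1Cl` stands lowest with 2.19 nM. Compound 3 `COC(=O)C1=C(C)N=C(C)/C(=C(\O)OC)C1c1cccc([N+](=O)[O-])c1` gives 3.98 nM, which lies within the scatter of compound 1, so no order between the two is claimed. Going by the values given here, compound 2 `COC(=O)C1=C(C)N=C(C)/C(=C(\O)OC)C1c1ccccc1I` gives 46.8 nM; the step of a 21-fold higher number from compound 1 to compound 2 (1.33 log units; beyond the scatter) is the only single-site step on record, and it is large. Compound 4 `COC(=O)C1=C(C)N=C(C)/C(=C(\O)OC)C1c1cccc(O)c1` differs from compound 1 by 3-hydroxyphenyl in place of 2-chlorophenyl on a saturated ring carbon. Among the compounds with values here, no measured step exchanges the whole aryl group for one carrying a hydrogen-bond donor, so the iodo step is at most a loose guide, while compound 3 shows that another aryl group can sit near compound 1. A moderate rise is expected, a 9.1-fold higher number from compound 1 to compound 4 (0.96 log units; beyond the scatter). Compound 4 is estimated at 20 nM, with a range of 4 nM to 100 nM.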

Compound 4, half-maximal effective concentration: 1000 nM
For compound 4 the middle estimate is 50-fold (1.70 log units) below the measured one; the measured number lies above the stated range.
By their numbers in this assay, from the lowest: compounds 1 and 3 (each within the scatter of the next); then compound 2; then compound 4.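

In this assay this saturated ring carbon proves far less forgiving of aryl exchange than compound 1, compound 2 and compound 3 indicated: 3-hydroxyphenyl in place of 2-chlorophenyl gives a 460-fold higher number from compound 1 to compound 4 (2.66 log units; beyond the scatter). Hydroxy in place of nitro on an aromatic carbon gives a 250-fold higher number from compound 3 to compound 4 (2.40 log units; beyond the scatter), so a large rise also occurs without chloro leaving. The iodo compound no longer marks the top of the series, with a 21-fold higher number from compound 2 to compound 4 (1.33 log units; beyond the scatter).

Nothing on hand gives a reason for these steps. Open, going by these compounds, is whether a methoxy or an amino group in place of the hydroxy would keep the number this high.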